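The source may report more compounds than this note shows. Statements on the series, on what has been measured and on what is new or still open speak of the compounds shown alone.

Measured so far:
compound 1 `C[C@H](NC(=O)c1nnn(Cc2ccc(F)cc2)c1C(F)(F)F)c1ccc(C(=O)O)cc1` gives > 10000 nM
compound 2 `C[C@H](NC(=O)c1nnn(Cc2ccc(C(F)(F)F)cc2)c1C(F)(F)F)c1ccc(C(=O)O)cc1` gives > 10000 nM

In a functional assay on CHO cells for antagonist activity at prostaglandin E2 receptor EP4 subtype (Homo sapiens), read by calcium flux, with a stated time of 15 min (on this read-out higher numbers stand for weaker inhibition and lower numbers for stronger inhibition), compound 1 gives > 10000 nM, which is a limit and not a number. In this assay compound 2 gives > 10000 nM, likewise a limit. The step that the two limits leave unreadable from compound 1 to compound 2 therefore cannot be read for size, and compound 2 stands only at the limit of > 10000 nM in this assay, at which 2 of the 2 values shown sit, with no measured number of its own.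

Compound 3 `C[C@H](NC(=O)c1nnn(Cc2cccc(C(F)(F)F)c2)c1C(F)(F)F)c1ccc(C(=O)O)cc1` differs from compound 2 by 3-(trifluoromethyl)phenyl in place of 4-(trifluoromethyl)phenyl on a saturated chain carbon bound to an aromatic nitrogen. Both have the same atoms, joined differently. Going by the values given here, no measured step bears on this change, and the one measured step is itself unreadable, so the only ground for an expectation is that compound 2 sits at the limit. Compound 3 is expected to sit near that limit as well, estimated at 10000 nM with a range of 3000 nM to 30000 nM. The expected step of a number no higher from compound 2 to compound 3 (the limit leaves the size open) is thus estimated as none beyond the scatter.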

Compound 3, half-maximal inhibitory concentration: > 10000 nM
Compound 3 was reported as a limit (the forecaster's own chance of this, stated with the estimate: 75%); the middle value lies on the limit itself.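

In this assay compound 3 gives > 10000 nM, a limit and not a number. Going by these compounds alone, no step among compound 1, compound 2 and compound 3 can be read. The compounds shown leave open whether 4-fluorophenyl, 4-(trifluoromethyl)phenyl and 3-(trifluoromethyl)phenyl differ at all, with every value at one limit: the limit of > 10000 nM in this assay, at which 3 of the 3 values shown sit.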